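The source may report more compounds than this note shows. Statements on the series, on what has been measured and on what is new or still open speak of the compounds shown alone.

Working notes on the series. For the measured compounds named here, compound 2 `CC/C=C\C[C@H]1C(=O)C=C[C@H]1CC(=O)OCCCC` stands highest of the two numbers so far in a functional assay on RAW264.7 cells (Mus musculus) for inhibition, read by ELISA, with a stated time of 24 h (on this read-out lower numbers stand for an effect already at smaller amounts and higher numbers for an effect only at larger amounts of compound), at 23000 nM; its nearest neighbour is compound 1 `CC/C=C\C[C@H]1C(=O)C=C[C@H]1CC(=O)OCC`, which gives 20000 nM in this assay, and the step of a 1.2-fold higher number from compound 1 to compound 2 (0.06 log units; within the scatter) lies within the scatter, so no order between the two can be read. Compound 3 `CC/C=C\C[C@H]1C(=O)C=C[C@H]1CC(=O)OCc1ccccc1` is not yet measured. It differs from compound 2 by phenyl in place of propyl on a saturated chain carbon bound to an oxygen next to a carbonyl group. Going by the values given here, the one measured step, a 1.2-fold higher number from compound 1 to compound 2 (0.06 log units; within the scatter), changed the same chain on the oxygen next to a carbonyl group and left the number where it was. Among the compounds with values here, no measured step brings a six-membered aromatic ring into this position, so the expectation rests on that single step alone. The step of a 1.2-fold lower number from compound 2 to compound 3 (0.06 log units; within the scatter) is therefore expected to stay within the scatter, with no preferred direction. Compound 3 is estimated at 20000 nM in this assay, with a range from 7000 nM to 55000 nM.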

Compound 3, half-maximal effective concentration: 20000 nM
Compound 3: middle estimate and measured number agree at the digits printed, and the stated range covers the measured number.
By their numbers in this assay, from the lowest: compounds 1, 3 and 2 (each within the scatter of the next).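

Phenyl in place of propyl gives a 1.2-fold lower number from compound 2 to compound 3 (0.06 log units; within the scatter), and phenyl in place of methyl gives no change at the digits printed from compound 1 to compound 3 (within the scatter), both in this assay. The earlier step changed only a saturated chain, whereas these steps show that a six-membered aromatic ring can enter on a saturated chain carbon bound to an oxygen next to a carbonyl group with the numbers remaining within the scatter, so the three compounds fall into no readable order. Nothing measured on these compounds offers an explanation for this flat result.

Going by these compounds, whether a carboxylic acid, an amine or a much longer chain at this place would move the number beyond the scatter remains open. On these data alone, it is also open whether a hydroxyl or methoxy group on the phenyl ring would leave the number unchanged.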